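A Large Group Added to Compound 1

This account rests on a few compounds, and the source may have more. Where it says the series, first, only, none or still open, it means among the compounds named here.

Measured in a functional assay for inhibition, with Homo sapiens as the target; on this read-out higher numbers stand for weaker inhibition and lower numbers for stronger inhibition:
- compound 1 `O=C(NC[C@H](NS(=O)(=O)c1ccccc1)C(=O)O)c1cc2cc(OCC3CCNCC3)ccc2[nH]1`: 13 nM
- compound 2 `Cn1c(C(=O)NC[C@H](NS(=O)(=O)c2ccccc2)C(=O)O)cc2cc(OCC3CCNCC3)ccc21`: 15 nM
- compound 3 `Nc1cc(COc2ccc3[nH]c(C(=O)NC[C@H](NS(=O)(=O)c4ccccc4)C(=O)O)cc3c2)ccn1`: 45 nM

Compound 1 sits at the low end of these numbers, level with compound 2 within the scatter: a 1.2-fold higher number from compound 1 to compound 2 (0.06 log units; within the scatter). Compound 3 lies clearly higher: a 3.5-fold higher number from compound 1 to compound 3 (0.54 log units; beyond the scatter). Compound 4 `CC1(C)C2CCC1(Cc1ccc(S(=O)(=O)N[C@@H](CNC(=O)c3cc4cc(OCC5CCNCC5)ccc4[nH]3)C(=O)O)cc1)C(=O)C2` differs from compound 1 by one change: a group of 11 heavy atoms (10 carbon, 1 oxygen; 2 five-membered non-aromatic rings of carbon only) in place of a hydrogen atom, on an aromatic carbon. Neither measured step touches that aromatic carbon, so they bear on it only loosely and the data leave the outcome open. Within the data shown here, the only step beyond the scatter, a 3.5-fold higher number from compound 1 to compound 3 (0.54 log units; beyond the scatter), was modest, so a modest rise in this assay is a cautious expectation, with a wide range. The expected change is a 2.3-fold higher number from compound 1 to compound 4 (0.36 log units; beyond the scatter). For compound 4 the estimated value is 30 nM, expected between 6 nM and 150 nM.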

Compound 4, half-maximal inhibitory concentration: 17 nM
For compound 4 the middle estimate is 1.8-fold (0.25 log units) above the measured one; measured number inside the range.
By their numbers in this assay, from the lowest: compounds 1, 2 and 4 (each within the scatter of the next); then compound 3.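

In this assay, among these compounds, the aromatic carbon of the six-membered aromatic ring of carbon only, untouched by the earlier steps, can now be read directly. Placing a group of 11 heavy atoms there in place of a hydrogen atom leaves the number level (a 1.3-fold higher number from compound 1 to compound 4 (0.12 log units; within the scatter)), so even this large group costs nothing beyond the scatter. Nothing available explains this tolerance.

Among the compounds shown here, with only this one group at the position, the effect of something different, such as a simple amine or a carboxylic acid, remains open. From the compounds shown here alone, whether the carbonyl within the group matters also remains open.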